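Growing the amine substituent on a chemokine receptor ligand

This account rests on a few compounds, and the source may have more. Where it says the series, first, only, none or still open, it means among the compounds named here.

Measured so far:
- compound 1, `CCCN(Cc1ccc(OCCN2C(=O)CCC2=O)c(C)c1)C1c2ccc(Cl)cc2CC1C(=O)O`: 1350 nM
- compound 2, `Cc1cc(CN(CC2CCCC2)[C@@H](CC(=O)O)c2ccc(Cl)cc2)ccc1OCCN1C(=O)CCC1=O`: 36 nM
- compound 3, `Cc1cc(CN(C)C(CC(=O)O)c2ccc(Cl)cc2)ccc1OCCn1c(=O)ccn(C)c1=O`: 1300 nM

All three compounds were tested in an assay on CHO cells for displacement of a labelled ligand from C-X-C chemokine receptor type 3 (Homo sapiens), with a stated time of 60 min; a higher number here means a weaker inhibitor, a lower number a stronger inhibitor. Compound 3 stands second highest of the three numbers. Its nearest neighbour is compound 1, whose value sits within the scatter of its own, so no order between the two can be read. The furthest is compound 2, which gives a number far lower and well beyond the scatter; compound 2 differs from compound 3 at more than one place, so only the two values themselves can be compared.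

The next compound, compound 4, is `CCCN(Cc1ccc(OCCn2c(=O)ccn(C)c2=O)c(C)c1)C(CC(=O)O)c1ccc(Cl)cc1`. It differs from compound 3 in one place: ethyl in place of hydrogen on a saturated chain carbon bound to an amine nitrogen. Cut one bond further out, the same difference reads methyl to propyl. Among the measured compounds shown here, since no single-change step between measured compounds is available, the expectation rests on what the values of compounds 2 and 3 show, namely that the larger amine substituent in this set comes with the lower number. A moderate downward step is expected in this assay, larger than the scatter. The step of a 3.7-fold lower number from compound 3 to compound 4 (0.57 log units; beyond the scatter) expresses this expectation.

Compound 4 is expected to give about 350 nM, with a likely range from 90 nM to 1300 nM.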

Compound 4, half-maximal inhibitory concentration: 123 nM
Estimate against measurement, compound 4: 2.8-fold (0.45 log units) above; the measured number falls inside the stated range.
By their numbers in this assay, from the lowest: compound 2; then compound 4; then compounds 3 and 1 (each within the scatter of the next).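

In this assay the change from methyl to propyl on the amine nitrogen gives an 11-fold lower number from compound 3 to compound 4 (1.02 log units; beyond the scatter) and is a large step, well beyond the usual scatter of repeated measurements. Among the compounds shown here, until now no two measured compounds differed in one place only, so no shift in the number could be tied to a single change. Here the rest of the structure stays the same, which ties this step to the longer chain and shows that this position responds strongly to the group placed on it, although no measurement at hand explains why.

What the compounds shown leave open is how far this trend runs, since a single step cannot tell whether a butyl or pentyl chain on the amine nitrogen would lower the number further or reverse the gain. Going by these compounds, it also remains open whether a chain carrying a hydroxyl group or a terminal amine would be tolerated at this position, and whether the same change from methyl to propyl would give a step of similar size on a different core.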